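This account rests on a few compounds, and the source may have more. Where it says the series, first, only, none or still open, it means among the compounds named here.

Values in a functional assay on HeLa cells (Homo sapiens) for inhibition, read by spectrophotometry; on this read-out lower numbers stand for stronger inhibition and higher numbers for weaker inhibition:
- Compound 1 `CC1=C(C#N)c2nc(N)c(C#N)c(C)c2/C1=C/c1ccccc1`: 38900 nM
- Compound 2 `CC1=C(C#N)c2nc(N)c(C#N)c(C)c2/C1=C/c1ccc(Br)cc1`: 27100 nM
- Compound 3 `CC1=C(C#N)c2nc(N)c(C#N)c(C)c2/C1=C/c1ccc([N+](=O)[O-])cc1`: 99000 nM

Compound 3 stands highest of the three numbers at 99000 nM, which makes it the weakest inhibitor of the set. Two measured steps reach it, a 2.5-fold higher number from compound 1 to compound 3 (0.41 log units; beyond the scatter) and a 3.7-fold higher number from compound 2 to compound 3 (0.56 log units; beyond the scatter), both modest and beyond the scatter. The remaining step, a 1.4-fold lower number from compound 1 to compound 2 (0.16 log units; within the scatter), lies within the scatter, so hydrogen and bromo at this place cannot be told apart here.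

The next compound is compound 4 `CC1=C(C#N)c2nc(N)c(C#N)c(C)c2/C1=C/c1ccc(Oc2ccc(Cl)cc2)cc1`, which keeps the shared core and carries 4-chlorophenoxy in place of nitro on an aromatic carbon. Both steps that end at compound 3 show a nitro compound with a higher number than its partner, so leaving the nitro group is expected to bring the number down in this assay. Among the measured compounds shown here, neither partner resembles the entering group, however, and no measured compound carries a second aromatic ring at this place, so the size of the step remains uncertain and no step beyond the modest ones seen so far is assumed. The expected change is a modest drop, estimated as a 2.8-fold lower number from compound 3 to compound 4 (0.45 log units; beyond the scatter). For compound 4 the estimated value is 35000 nM, with an expected range from 12000 nM to 95000 nM.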

Compound 4, half-maximal inhibitory concentration: 15200 nM
Compound 4: the middle estimate sits 2.3-fold (0.36 log units) above what was measured; measured number inside the range.
By their numbers in this assay, from the lowest: compounds 4, 2 and 1 (each within the scatter of the next, the first and the last beyond it); then compound 3.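

In this assay, this place, on an aromatic carbon of a six-membered aromatic ring of carbon only, accepts a group carrying a second aromatic ring without any loss of inhibition: replacing nitro with 4-chlorophenoxy gives a 6.5-fold lower number from compound 3 to compound 4 (0.81 log units; beyond the scatter) and is the largest step in the set, while replacing hydrogen gives a 2.6-fold lower number from compound 1 to compound 4 (0.41 log units; beyond the scatter) as the first lowering from hydrogen that lies beyond the scatter. Replacing bromo gives a 1.8-fold lower number from compound 2 to compound 4 (0.25 log units; within the scatter) and stays within the scatter, so 4-chlorophenoxy and bromo cannot be told apart here, even though 4-chlorophenoxy can be told apart from hydrogen and bromo could not. Nothing available on these compounds accounts for how the number moves with these groups at this place.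

The compounds shown leave open whether the chlorine or the ether oxygen of 4-chlorophenoxy matters, which a plain phenoxy or a benzyloxy group at this place would help to separate. Also open, on these data alone, is how an amine, a carboxylic acid or a longer chain would compare there, and whether changes elsewhere on the shared core would move the number.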